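The source may report more compounds than this note shows. Statements on the series, on what has been measured and on what is new or still open speak of the compounds shown alone.

Measured compounds in a functional assay on HTB-54 cells (Homo sapiens) for cytotoxicity, read by MTT assay, with a stated time of 72 h; on this read-out lower numbers stand for stronger inhibition of growth and higher numbers for weaker inhibition of growth:

Compound 1 `CSc1ccc(CNc2nc(SC)nc3ncccc23)cc1` gives 14800 nM.
Compound 2 `COc1ccc(CNc2nc(SC)nc3ncccc23)cc1` gives only a limit of the assay, > 100000 nM.
Compound 3 `COc1ccc(CNc2nc(SC)nc3ccccc23)cc1` gives only a limit of the assay, > 100000 nM.

Within the data shown here, two of the three values sit at the limit of > 100000 nM in this assay, at which 2 of the 3 values shown sit, so the one counted step rests on a limit at one end: an at least 6.7-fold lower number from compound 2 to compound 1 (0.82 log units; beyond the scatter), the change being (methylsulfanyl in place of methoxy on an aromatic carbon).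

Compound 3 carries a different core from compound 2; the difference between the two cores is not broken down here. Compound 4 `CSc1ccc(CNc2nc(SC)nc3ccccc23)cc1` is the not yet measured partner of compound 3 in which the same change is made, (methylsulfanyl in place of methoxy on an aromatic carbon); the place of the change is the same in both pairs.

The expectation for compound 4 is that the change repeats at least part of the step seen from compound 2 to compound 1, since compound 3 itself gives a limit; the step is estimated as an at least 3.3-fold lower number from compound 3 to compound 4 (0.52 log units; beyond the scatter). Compound 4 is expected to give 30000 nM, within 8000 nM to 100000 nM, with a real chance that only a limit is again reported.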

Compound 4, concentration for total growth inhibition: 44500 nM
Compound 4: the middle estimate sits 1.5-fold (0.17 log units) below what was measured; the measured number falls inside the stated range.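

In this assay, methylsulfanyl in place of methoxy on an aromatic carbon again gives a lower number on the second core, with an at least 2.2-fold lower number from compound 3 to compound 4 (0.35 log units; beyond the scatter), so the direction of the step carries over between the two pairs shown. Whether the size of the step also carries over cannot be said: the same change on two cores in this assay, an at least 6.7-fold lower number (0.82 log units; beyond the scatter) from compound 2 to compound 1 and an at least 2.2-fold lower number (0.35 log units; beyond the scatter) from compound 3 to compound 4; the limit leaves it open whether they differ Compound 2 and compound 3, the starting points of the two steps, each give only a limit of the assay and not a number, so neither step has a known full size: the limit of > 100000 nM in this assay, at which 2 of the 4 values shown sit.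

The compounds shown leave open whether the lower number stays with a longer chain on the sulfur, such as ethylsulfanyl, or also appears with an amine such as dimethylamino at the same place. Also open, on these data alone, is what would follow from replacing the methylsulfanyl group on the shared core, which all four compounds carry, with a different group such as an amine.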